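Replacing the Aminotriazole Group of a Strong Inhibitor

The source may hold more compounds than are shown below. What is called first, only, known or untested is meant among the compounds shown, and "the series" means these compounds.

Among the measured compounds shown here, in a functional assay (aorta) with Rattus norvegicus as the target (a higher number here means a weaker inhibitor, a lower number a stronger inhibitor), compound 1 `CCO/C(O)=C1\C(COCCNc2n[nH]c(N)n2)=NC(C)=C(C(=O)OC)C1c1cccc(Cl)c1Cl` gives 6.31 nM, the lowest of the three numbers measured so far. Compound 2 `CCO/C(O)=C1\C(COCCNc2n[nH]c(N)n2)=NC(C)=C(C(=O)OC)C1c1cccc(Cl)c1` gives 126 nM, and compound 3 `CCO/C(O)=C1\C(COCCNc2n[nH]c(N)n2)=NC(C)=C(C(=O)OC)C1c1cccnc1Cl` gives 316 nM. The measured steps of a 20-fold higher number from compound 1 to compound 2 (1.30 log units; beyond the scatter) and a 50-fold higher number from compound 1 to compound 3 (1.70 log units; beyond the scatter) are both large, but each alters only the chlorinated aromatic group. Compound 4 `CCO/C(O)=C1\C(COCC/N=C(/N)S)=NC(C)=C(C(=O)OC)C1c1cccc(Cl)c1Cl` differs elsewhere: a group of 4 heavy atoms (1 carbon, 2 nitrogen, 1 sulfur; no ring) in place of a group of 7 heavy atoms (2 carbon, 5 nitrogen; one five-membered aromatic ring with 3 hetero atoms), on a saturated chain carbon, two bonds along the chain from an oxygen on a saturated carbon. For the measured compounds named here, no measured step touches this place, so none can size the change directly, and any forecast stays loose. With compound 1 at 6.31 nM, the best of the series, a higher number is expected rather than a lower one. The expected step is a 4.0-fold higher number from compound 1 to compound 4 (0.60 log units; beyond the scatter). Compound 4 is estimated at 25 nM, with an expected range of 3 nM to 200 nM.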

Compound 4, half-maximal inhibitory concentration: 1 nM
Beside the measured number, compound 4's estimate is 25-fold (1.40 log units) above it, and the stated range ends above it.
By their numbers in this assay, from the lowest: compound 4; then compound 1; then compound 2; then compound 3.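

Putting the smaller, ringless group in place of (5-amino-1H-1,2,4-triazol-3-yl)amino gives a 6.3-fold lower number from compound 1 to compound 4 (0.80 log units; beyond the scatter) in this assay so the aromatic triazole ring is not needed here for a low number. Among the compounds shown here, the earlier compounds changed only the chlorinated aromatic group, so this is the first sign that this place on the chain also moves the number, and that it can go lower than compound 1. Nothing measured on these groups explains the step.

From the compounds shown here alone, whether the sulfur matters stays open, and a urea or a plain amine at this place would test it. Also open, going by these compounds, is whether the same swap holds with the 3-chlorophenyl group of compound 2.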